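From methyl to butyl on the shared core

The source may report more compounds than this note shows. Statements on the series, on what has been measured and on what is new or still open speak of the compounds shown alone.

In a functional assay on the whole organism with Mus musculus as the target (on this read-out higher numbers stand for an effect only at larger amounts of compound and lower numbers for an effect already at smaller amounts), compound 1 (`CN1CCN(C(=O)/C=C/c2cccc(C(F)(F)F)c2)CC1`) returns > 100 mg/kg as a limit and not a number. Among the measured compounds shown here, compound 2 (`CN1C(=O)CCC1(O)c1cccc(C(F)(F)F)c1`) gives 133 mg/kg in this assay and so holds the only actual number so far. Compound 3 (`CCCCN1C(=O)CCC1(O)c1cccc(C(F)(F)F)c1`) keeps the core of compound 2 and differs in one place: propyl in place of hydrogen on a saturated chain carbon bound to an amide-type nitrogen in a ring on a saturated chain carbon bound to an amide-type nitrogen in a ring, so that methyl becomes butyl. For the measured compounds named here, no measured step between close relatives is available to size this change, which leaves the expectation weak: a small move in this assay toward effect at smaller amounts, possibly none beyond the scatter. The estimated 1.3-fold lower number from compound 2 to compound 3 (0.12 log units; within the scatter) is accordingly modest. Compound 3 is expected at 100 mg/kg with an estimated range from 40 mg/kg to 250 mg/kg in this read-out.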

Compound 3, dose for half-maximal effect: > 200 mg/kg
Compound 3 ended at the assay's limit; the forecaster's own chance of this, stated with the estimate: 25%; middle value at least 2.0-fold (0.30 log units) from the limit.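

Among the compounds shown here, replacing methyl with butyl on a saturated chain carbon bound to an amide-type nitrogen in a ring gives the first step at this position: in this assay, an at least 1.5-fold higher number from compound 2 to compound 3 (0.17 log units; that floor lies within the scatter). The printed floor of this step does not establish a real loss, but the longer chain also shows no shift toward effect at smaller amounts. The full size of the step stays open because compound 3 stands at a limit of the assay: the limit of > 200 mg/kg in this assay, at which 1 of the 3 values shown sits.

From the compounds shown here alone, whether the outcome at this position follows chain length remains open, as a step through ethyl or propyl, or to a chain ending in an amine or a carboxylic acid, would be needed to show it. For the compounds shown here, compound 1 differs from both other compounds in more than one place, so it offers no step at this position.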